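Ring size at the pyrazole nitrogen substituent

This account rests on a few compounds, and the source may have more. Where it says the series, first, only, none or still open, it means among the compounds named here.

Compound 1 `Cc1ccc(C(=O)Nc2cccc(C(F)(F)F)c2)cc1-c1ccc2c(-c3cnn(CC(C)O)c3)n[nH]c2c1` gives 3.7 nM in an assay on isolated protein for inhibition of Discoidin domain-containing receptor 2 (Homo sapiens), read by ELISA, with a stated time of 60 min; on this read-out lower numbers stand for stronger inhibition and higher numbers for weaker inhibition. Among the compounds with values here, compound 2 `Cc1ccc(C(=O)Nc2cccc(C(F)(F)F)c2)cc1-c1ccc2c(-c3cnn(C4CCOC4)c3)n[nH]c2c1` gives 6.2 nM in this assay, and the only other number, from compound 1, sits within the scatter of it, the step being a 1.7-fold higher number from compound 1 to compound 2 (0.22 log units; within the scatter). Compound 3 `Cc1ccc(C(=O)Nc2cccc(C(F)(F)F)c2)cc1-c1ccc2c(-c3cnn(C4CCCCO4)c3)n[nH]c2c1` differs from compound 2 by oxan-2-yl in place of oxolan-3-yl on an aromatic nitrogen. Within the data shown here, only the step from compound 1 to compound 2 bears on this change, as it also swaps the substituent on the same aromatic nitrogen, and it stayed within the scatter. Compound 3 is therefore expected to show no step beyond the scatter in this assay, the estimated step being a 1.1-fold higher number from compound 2 to compound 3 (0.05 log units; within the scatter). For compound 3 the estimate in this assay is 7 nM, with a range from 3 nM to 18 nM.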

Compound 3, half-maximal inhibitory concentration: 5.2 nM
Estimate against measurement, compound 3: 1.3-fold (0.13 log units) above, and the stated range covers the measured number.
By their numbers in this assay, from the lowest: compounds 1, 3 and 2 (each within the scatter of the next).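

In this assay the substituent on the aromatic nitrogen goes from the five-membered oxolan-3-yl to the six-membered oxan-2-yl with no step beyond the scatter: a 1.2-fold lower number from compound 2 to compound 3 (0.08 log units; within the scatter). The open-chain 2-hydroxypropyl and oxan-2-yl also stay within the scatter of each other, with a 1.4-fold higher number from compound 1 to compound 3 (0.15 log units; within the scatter), so compound 1, compound 2 and compound 3 sit at one level and none goes against this. Ring size and the point of attachment on the ring change together in the step to compound 3, so neither can be read alone.

All three groups carry oxygen, so a plain cyclohexyl ring would test whether that atom matters at this position. A piperidin-4-yl amine or a carboxylic acid on a short chain would show whether this level holds beyond oxygen-bearing groups. No measurement here accounts for these small steps.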